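Methoxy for chloro on a sulfonyl aryl ring

A few compounds are considered here, and "the series" means these few. Any claim that something is new, unique, unknown or untested is made for them only; others in the source may bear on it.

Compounds measured:
compound 1, `O=S(=O)(c1cccc(F)c1)c1cccc2oc(N3CCNCC3)nc12`: 54 nM
compound 2, `O=S(=O)(c1ccc(F)cc1)c1cccc2oc(N3CCNCC3)nc12`: 64 nM
compound 3, `O=S(=O)(c1cccc(Cl)c1)c1cccc2oc(N3CCNCC3)nc12`: 31 nM

In an assay on HeLa cells for displacement of a labelled ligand from 5-hydroxytryptamine receptor 6 (Homo sapiens) (a lower number here means a stronger inhibitor, a higher number a weaker inhibitor), compound 3 gives the lowest number of the three, though a 1.7-fold lower number from compound 1 to compound 3 (0.24 log units; within the scatter) lies within the scatter and only a 2.1-fold lower number from compound 2 to compound 3 (0.31 log units; beyond the scatter) goes beyond it. Compound 4, `COc1cccc(S(=O)(=O)c2cccc3oc(N4CCNCC4)nc23)c1`, differs from compound 3 by methoxy in place of chloro on an aromatic carbon. Among the measured compounds shown here, no measured pair involves methoxy; the nearest guide is a 1.7-fold lower number from compound 1 to compound 3 (0.24 log units; within the scatter), a halogen swap at the same carbon that stayed within the scatter. Compound 4 is therefore expected to give a step of a 1.5-fold higher number from compound 3 to compound 4 (0.16 log units; within the scatter) that does not clearly leave the scatter. Compound 4 is estimated at 45 nM, with a range from 18 nM to 115 nM.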

Compound 4, inhibition constant: 25 nM
Estimate against measurement, compound 4: 1.8-fold (0.26 log units) above; low and high end bracket the measured number.
By their numbers in this assay, from the lowest: compounds 4, 3, 1 and 2 (each within the scatter of the next, the first and the last beyond it).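

In this assay, this assay, methoxy on this aromatic carbon, meta to a large group, sits level with chloro (a 1.2-fold lower number from compound 3 to compound 4 (0.09 log units; within the scatter)), so the position accepts a group of two heavy atoms with a hydrogen-bond acceptor without a clear loss. Where chloro stayed within the scatter of fluoro, methoxy goes beyond it (a 2.2-fold lower number from compound 1 to compound 4 (0.33 log units; beyond the scatter)), and the gap also exceeds the scatter against the 4-fluorophenyl compound (a 2.6-fold lower number from compound 2 to compound 4 (0.41 log units; beyond the scatter)). Nothing available explains these steps.

The compounds shown leave open whether ethoxy, hydroxyl or an amine on this carbon would keep the number. They also leave open how methoxy would fare where compound 2 carries its fluoro.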